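The compounds below may be only part of what the source reports. "The series", "measured", "known", "first", "only" and "open" are said of these compounds alone.

Of the compounds shown here, two of one shared core have been tested in a functional assay on HL-60 cells (Homo sapiens) for antiproliferative activity, with a stated time of 24 h; a higher number here means a weaker inhibitor, a lower number a stronger inhibitor. Compound 1, `NC(=O)c1c(NC(=O)c2ccccc2Cl)sc2c1CCN(Cc1ccc([N+](=O)[O-])cc1)C2`, gives 11400 nM in this assay. Compound 2, `NC(=O)c1c(NC(=O)c2ccccc2F)sc2c1CCN(Cc1cccc(Cl)c1)C2`, gives 19800 nM in this assay. The two numbers lie within the usual scatter of each other, so compound 2 cannot be called weaker or stronger than compound 1; both act only at rather high concentrations.

Compound 3, `NC(=O)c1c(NC(=O)c2ccccc2F)sc2c1CCN(C(=S)Nc1ccccc1Cl)C2`, is not yet measured. It differs from compound 2 in one place: a group of 10 heavy atoms (7 carbon, 1 nitrogen, 1 sulfur, 1 chlorine; one six-membered aromatic ring of carbon only) in place of a group of 8 heavy atoms (7 carbon, 1 chlorine; one six-membered aromatic ring of carbon only), on an amine nitrogen in a ring. The new group brings a nitrogen and a sulfur into the position on the amine nitrogen in the ring that the 3-chlorobenzyl group occupied before, together with one hydrogen-bond donor and one hydrogen-bond acceptor where there were none.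

Among the compounds with values here, no measured pair in this small set shows what such a change does, so there is nothing to lean on beyond the two values given. Compound 3 is therefore expected to stay close to compound 2, with a step of a 1.3-fold lower number from compound 2 to compound 3 (0.12 log units; within the scatter) that may well fall inside the scatter, and its value in this assay is estimated at 15000 nM, within a range from 5000 nM to 45000 nM.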

Compound 3, half-maximal inhibitory concentration: 12500 nM
Compound 3: the middle estimate sits 1.2-fold (0.08 log units) above what was measured; the measured number falls inside the stated range.
By their numbers in this assay, from the lowest: compounds 1, 3 and 2 (each within the scatter of the next).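

In this assay, within the data shown here, compounds 2 and 3 form the first pair in this set that differs in one place only, and the exchange gives a 1.6-fold lower number from compound 2 to compound 3 (0.20 log units; within the scatter) at the amine nitrogen in the ring. This position therefore accepts more than the 3-chlorobenzyl group: the new group adds a nitrogen, a sulfur, a double bond outside aromatic rings, a hydrogen-bond donor and a hydrogen-bond acceptor, yet the two compounds cannot be told apart by this read-out. One exchange at one position is a single observation, however, and it does not show that the position is generally insensitive to change. Nothing available explains why two such different groups give numbers this close.

From the compounds shown here alone, it remains open whether a quite different group on this nitrogen, such as a free amine, a carboxylic acid or a longer alkyl chain, would produce a step beyond the scatter. It is also open whether the chlorine on the aromatic ring of the new group matters, as the compounds shown offer no version with a hydrogen or a methoxy group in its place.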